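Replacing the Cyclohexyl Group of Compound 1

The source may hold more compounds than are shown below. What is called first, only, known or untested is meant among the compounds shown, and "the series" means these compounds.

In an ADME assay on L6 cells (Rattus norvegicus) for cytotoxicity (a higher number here means a weaker inhibitor, a lower number a stronger inhibitor), compound 1 `CCNC(=O)c1noc(-c2cc(C(C)C)c(O)cc2O)c1NC(=O)C1CCC(OC)CC1` gives 15 nM. Within the data shown here, this is the lower of the two numbers so far, as compound 2 `CCNC(=O)c1noc2c1CN(C(=O)c1cc(C(C)C)c(O)cc1O)CC2` gives 110 nM, and the gap between them lies beyond the scatter. Compound 3 `CCNC(=O)c1noc(-c2cc(C(C)C)c(O)cc2O)c1NC(=O)c1cc(CC)on1` has not yet been measured. It keeps the core of compound 1 and differs in one place: 5-ethyl-1,2-oxazol-3-yl in place of 4-methoxycyclohexyl on a carbonyl carbon. There, 5-ethyl-1,2-oxazol-3-yl stands in place of 4-methoxycyclohexyl on a carbonyl carbon. No measured pair among these compounds shows a single change of this kind, so the data give no direct guide. The expectation therefore takes compound 1 at 15 nM as its anchor. A modest rise in this assay is expected, about the size of the scatter, with an estimated step of a 2.0-fold higher number from compound 1 to compound 3 (0.30 log units; within the scatter). For compound 3 the estimated value is 30 nM, within an expected range of 8 nM to 120 nM.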

Compound 3, half-maximal inhibitory concentration: 20 nM
The estimate for compound 3 lay 1.5-fold (0.18 log units) above the measured number; the range from low to high includes it.
By their numbers in this assay, from the lowest: compounds 1 and 3 (each within the scatter of the next); then compound 2.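

In this assay, among these compounds, putting 5-ethyl-1,2-oxazol-3-yl in place of 4-methoxycyclohexyl on a carbonyl carbon gives a 1.3-fold higher number from compound 1 to compound 3 (0.12 log units; within the scatter), the first step in this set that changes a single place. At this position, therefore, a five-membered aromatic ring with 2 hetero atoms can stand in place of a six-membered non-aromatic ring of carbon only, with no change that can be told from the scatter. No measurement at hand accounts for this result.

The compounds shown leave open whether the ethyl on the new ring matters, as neither a methyl nor a longer chain appears there. They also leave open how this position would respond to an amine or a carboxylic acid on the ring.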